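The source may report more compounds than this note shows. Statements on the series, on what has been measured and on what is new or still open speak of the compounds shown alone.

Measured compounds:
- compound 1, `O=C(c1cccc(Cl)c1)N1CCC(NS(=O)(=O)c2cc(S(=O)(=O)c3ccccc3)ccc2C(F)(F)F)CC1`: 6300 nM
- compound 2, `N#Cc1cccc(S(=O)(=O)N2CCC(NS(=O)(=O)c3cc(S(=O)(=O)c4ccccc4)ccc3C(F)(F)F)CC2)c1`: 6300 nM
- compound 3, `O=C(O)c1ccc(N2CCC(NS(=O)(=O)c3cc(S(=O)(=O)c4ccccc4)ccc3C(F)(F)F)CC2)cc1`: 25000 nM

All three share one core and differ only in the group on the amine nitrogen in the ring. In a physicochemical assay for solubility (a lower number here means a less soluble compound, a higher number a more soluble compound), compound 1 gives 6300 nM and compound 2 gives 6300 nM; the two stand level, and together they are the lowest of the three numbers. Compound 3 lies furthest from them, with a 4.0-fold higher number from compound 1 to compound 3 (0.60 log units; beyond the scatter) and a 4.0-fold higher number from compound 2 to compound 3 (0.60 log units; beyond the scatter). The remaining pair shows no change at the digits printed from compound 1 to compound 2 (within the scatter).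

Compound 4, `CC(C)(C)OC(=O)N1CCC[C@H]1C(=O)N1CCC(NS(=O)(=O)c2cc(S(=O)(=O)c3ccccc3)ccc2C(F)(F)F)CC1`, has not yet been measured in this assay. It changes compound 1 in a different place: 1-(tert-butoxycarbonyl)pyrrolidin-2-yl in place of 3-chlorophenyl on a carbonyl carbon. The carbonyl group itself stays; only the group attached to it is exchanged. Going by the values given here, none of the measured steps touches this position, so no measured step bears on it directly. What the measured steps do show is that exchanging the whole group on the amine nitrogen in the ring moved this assay by at most a modest amount, as in a 4.0-fold higher number from compound 1 to compound 3 (0.60 log units; beyond the scatter), or not at all, as in no change at the digits printed from compound 1 to compound 2 (within the scatter).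

On that basis a small step upward, within or just beyond the scatter, is expected for compound 4, namely a 1.9-fold higher number from compound 1 to compound 4 (0.28 log units; within the scatter). Compound 4 is therefore estimated at 12000 nM, within a range of 4000 nM to 40000 nM.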

Compound 4, solubility: 25000 nM
Estimate against measurement, compound 4: 2.1-fold (0.32 log units) below, within the range that was stated.
By their numbers in this assay, from the lowest: compounds 1 and 2 (each within the scatter of the next); then compounds 3 and 4 (each within the scatter of the next).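

Until now, every measured change replaced the whole group on the amine nitrogen in the ring, whereas compound 4 keeps the carbonyl and exchanges only the group attached to it. In this assay, that narrower exchange gives a 4.0-fold higher number from compound 1 to compound 4 (0.60 log units; beyond the scatter), so the group on this carbonyl carbon can by itself move the number beyond the scatter. The exchange alters several things at once, replacing a six-membered aromatic ring of carbon only with a five-membered non-aromatic ring and adding 2 hydrogen-bond acceptors and a defined stereocentre, and nothing measured here links the step to any one of these features.

On these data alone, it remains open which part of 1-(tert-butoxycarbonyl)pyrrolidin-2-yl goes with the higher number, the tert-butoxycarbonyl group or the pyrrolidine ring itself. A pyrrolidin-2-yl group with a free ring amine, a simple open alkyl chain on the same carbonyl, or the opposite stereocentre would each separate these parts, and the compounds shown include none of them.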